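Replacing a Bulky Side Chain with a Small Carbamoyl Group

This account rests on a few compounds, and the source may have more. Where it says the series, first, only, none or still open, it means among the compounds named here.

Measured so far:
Compound 1 `CCn1c(=O)n(C2OC(CO)[C@@H](O)[C@H]2O)c2nc(N)nc(O)c21` gives 82% in a functional assay on the whole organism (B cells) with Mus musculus as the target; on this read-out higher numbers stand for larger maximal responses and lower numbers for smaller maximal responses.
Compound 2 `Nc1nc(O)c2c(n1)n(C1OC(CO)[C@@H](O)[C@H]1O)c(=O)n2CC(O)CSc1ccccc1` gives 12% in this assay.

Among the measured compounds shown here, compound 2 stands lowest of the two measured numbers, and the only step known, a number 70 percentage points lower from compound 1 to compound 2 (beyond the scatter), is a large drop. Compound 3 `NC(=O)Cn1c(=O)n(C2OC(CO)[C@@H](O)[C@H]2O)c2nc(N)nc(O)c21` reverses most of that growth: carbamoyl in place of 1-hydroxy-2-(phenylsulfanyl)ethyl on a saturated chain carbon bound to an aromatic nitrogen. Since the small-to-large step cost so much, the step back to a small group is expected to recover much of it in this assay, so the estimated step is a number 53 percentage points higher from compound 2 to compound 3 (beyond the scatter). Compound 3 is therefore expected to reach about 65%, within a range of 35% to 90%.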

Compound 3, largest response reached (reported as maximal response), in percent of the reference or control that the assay uses: 32%
Beside the measured number, compound 3's estimate is 33 percentage points above it, outside the stated range (below it).
By their numbers in this assay, from the lowest: compound 2; then compound 3; then compound 1.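

In this assay, carbamoyl in place of 1-hydroxy-2-(phenylsulfanyl)ethyl gives a number 20 percentage points higher from compound 2 to compound 3 (beyond the scatter) and so restores only part of what the larger group lost. Set against methyl, carbamoyl still gives a number 50 percentage points lower from compound 1 to compound 3 (beyond the scatter) and shows that a small group at this place does not by itself bring back a high response. Nothing available explains why carbamoyl falls short of methyl.

Going by these compounds, it stays open how an amine, a carboxylic acid or a longer plain carbon chain would behave on this saturated chain carbon bound to an aromatic nitrogen.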